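A few compounds are considered here, and "the series" means these few. Any claim that something is new, unique, unknown or untested is made for them only; others in the source may bear on it.

In an ADME assay on CCRF-CEM cells (Homo sapiens) for cytotoxicity, read by MTT assay, with a stated time of 4 days (on this read-out higher numbers stand for lower toxicity in this test and lower numbers for higher toxicity in this test), compound 1 `Cc1cc(C)cc(Cc2cc(Cl)ccc2OCCn2ccc(=O)[nH]c2=O)c1` gives > 200000 nM, which is a limit of the assay and not a number. Compound 2 `Cc1cc(C)cc(C(O)c2cc(Cl)ccc2OCCn2ccc(=O)[nH]c2=O)c1` gives > 20000 nM, which is also a limit. Among the measured compounds shown here, the only measured step is a step that the two limits leave unreadable from compound 1 to compound 2. That change concerns a saturated chain carbon rather than an aromatic carbon, and it offers no size to carry over. Compound 3 `Cc1cc(C)cc(Cc2cc(Br)ccc2OCCn2ccc(=O)[nH]c2=O)c1` differs from compound 1 by bromo in place of chloro on an aromatic carbon, with bromo in place of chloro on an aromatic carbon. With no readable step to guide the forecast, no change beyond the usual scatter is expected in this assay, and another limit is the likeliest report. The expected step is a number no higher from compound 1 to compound 3 (the limit leaves the size open). For compound 3 the estimated value is 200000 nM, with an expected range from 60000 nM to 400000 nM.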

Compound 3, half-maximal cytotoxic concentration in the CCRF-CEM assay: > 200000 nM
Compound 3: no number, only a limit; the forecaster's own chance of this, stated with the estimate: 70%; the middle value lies on the limit itself.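

In the CCRF-CEM assay compound 1 gives > 200000 nM, which is a limit and not a number. In the CCRF-CEM assay compound 3 gives > 200000 nM, which is also a limit and not a number. No step can be read between them. The compounds shown leave open whether bromo in place of chloro on an aromatic carbon changes the half-maximal cytotoxic concentration at all. In a physicochemical assay for solubility (a lower number here means a less soluble compound, a higher number a more soluble compound), compound 1 gives 900 nM and compound 3 gives 1200 nM, with a 1.3-fold higher number from compound 1 to compound 3 (0.12 log units; within the scatter).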